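The source may report more compounds than this note shows. Statements on the series, on what has been measured and on what is new or still open speak of the compounds shown alone.

Within the data shown here, in an ADME assay on microsomes from liver (Mus musculus) for metabolic stability, using NADPH, with a stated time of 10 min (a higher number here means that more of the compound is left, a lower number that less of the compound is left), compound 1 (`CN(C[C@H]1Cc2ncccc2CN1)[C@H]1CCCc2cccnc21`) gives 53%, the higher of the two numbers so far. Its stereoisomer, compound 2 (`CN(C[C@@H]1Cc2ncccc2CN1)[C@H]1CCCc2cccnc21`), gives 0%. Among the measured compounds shown here, the only measured step is a number 53 percentage points lower from compound 1 to compound 2 (beyond the scatter), and it can be traced to the fact that compounds 1 and 2 differ only in the configuration as drawn.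

Compound 3 (`NC/C=C/CN(C[C@H]1Cc2ncccc2CN1)[C@H]1CCCc2cccnc21`) keeps the configuration of compound 1 and carries 3-aminoprop-1-en-1-yl in place of hydrogen on a saturated chain carbon bound to an amine nitrogen: a 3-aminoprop-1-en-1-yl in place of hydrogen. The step to compound 2 involves configuration alone, so it gives no direction for this change. Its size, a number 53 percentage points lower from compound 1 to compound 2 (beyond the scatter), does show that a large move is possible within this pair, which argues for a wide range. The expected step is a number 8 percentage points lower from compound 1 to compound 3 (within the scatter), so no shift beyond the scatter is anticipated. The estimated value for compound 3 is 45%, with an expected range of 12% to 80%.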

Compound 3, percent of the compound remaining: 37%
The estimate for compound 3 lay 8 percentage points above the measured number, and the stated range covers the measured number.
By their numbers in this assay, from the lowest: compound 2; then compound 3; then compound 1.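

Placing 3-aminoprop-1-en-1-yl on a saturated chain carbon bound to an amine nitrogen gives the first read-out for a change of substituent on the core of compound 1 in this assay: a number 16 percentage points lower from compound 1 to compound 3 (beyond the scatter). Among these compounds, this position therefore takes a group of this size with a modest step, smaller than the one seen for the change of configuration, a number 53 percentage points lower from compound 1 to compound 2 (beyond the scatter). Nothing at hand gives a cause for the step to compound 3.

Going by these compounds, it remains open whether the step follows the amine or the double bond of the entering group, which a saturated propyl chain, a hydroxypropyl chain or a carboxylic acid at the same place could separate. Also open, on these data alone, is whether the same group would behave alike on the configuration of compound 2.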